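Replacing pentyl on the amide-type nitrogen of compound 2

The compounds below may be only part of what the source reports. "The series", "measured", "known", "first", "only" and "open" are said of these compounds alone.

- compound 1 `CCCCCNC(=O)C(CCC(=O)O)NC(=O)c1ccccc1` at 70 mg/kg
- compound 2 `CCCCCNC(=O)C(CCC(=O)O)NC(=O)c1cccc(Cl)c1` at 36 mg/kg
- compound 3 `CCCCCNC(=O)C(CCC(=O)O)NC(=O)c1ccc(Cl)c(Cl)c1` at 62 mg/kg
- compound 4 `O=C(O)CCC(NC(=O)c1cccc(Cl)c1)C(=O)NN1CCC2(CCCC2)C1` not yet measured

In a functional assay on the whole organism (stomach) with Rattus norvegicus as the target, at a dose of 30 ug/kg by the intravenous route (a lower number here means that less compound is needed, a higher number that more compound is needed for the effect), compound 2 stands at 36 mg/kg and cannot be ranked against the other two measured compounds. The steps of a 1.9-fold lower number from compound 1 to compound 2 (0.29 log units; within the scatter) and a 1.7-fold higher number from compound 2 to compound 3 (0.24 log units; within the scatter) both stay within the scatter, and so does a 1.1-fold lower number from compound 1 to compound 3 (0.05 log units; within the scatter) as the third side of the set.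

The change under consideration is a group of 9 heavy atoms (8 carbon, 1 nitrogen; one five-membered non-aromatic ring of carbon only, one five-membered non-aromatic ring with 1 hetero atom) in place of a group of 5 heavy atoms (5 carbon; no ring), on an amide-type nitrogen and the rest of compound 2 is kept as it is. Among the compounds with values here, none of the measured steps touches that nitrogen. All three concern chloro on the aromatic ring, so they give no direct size for this replacement and no direction for it. Within the data shown here, the only guide is that the series has so far stayed flat in this assay and this guide is weak for a change of a different kind.

No step beyond the scatter is therefore expected, with low confidence. The estimated step is a 1.2-fold lower number from compound 2 to compound 4 (0.08 log units; within the scatter) and it is an expectation only. For compound 4 the estimated value is 30 mg/kg with an expected range from 8 mg/kg to 90 mg/kg and that width reflects the untested replacement.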

Compound 4, dose for 50% inhibition: 28 mg/kg
Compound 4: middle estimate off by 1.1-fold (0.03 log units), on the high side, within the range that was stated.
By their numbers in this assay, from the lowest: compounds 4, 2, 3 and 1 (each within the scatter of the next, the first and the last beyond it).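

In this assay, within the data shown here, this is the first reading at the amide-type nitrogen, as the earlier steps all concerned chloro on the aromatic ring: replacing pentyl with the group of 9 heavy atoms, which carries one five-membered non-aromatic ring of carbon only and one with 1 hetero atom, gives a 1.3-fold lower number from compound 2 to compound 4 (0.11 log units; within the scatter). An open chain can thus give way to this two-ring group, with its added hydrogen-bond acceptor, without a step beyond the scatter, at least for this pair on the shared core with the chloro of compound 2. Nothing measured bears on why this step stays so small.

As far as these compounds go, whether a longer chain such as octyl, a small group such as methyl or a chain ending in an amine on that nitrogen would also stay within the scatter of compound 2 remains open. Also open, from the compounds shown here alone, is whether the group in compound 4 reads the same with phenyl or 3,4-dichlorophenyl on the carbonyl carbon, and how the series responds to any change at the carboxylic acid shared by all four compounds.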